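Hydroxycyclobutyl for hydroxyethyl, transferred to a second core

The compounds below may be only part of what the source reports. "The series", "measured", "known", "first", "only" and "open" are said of these compounds alone.

Compound 1 `COc1cc(C(=O)N2CC(C)OCC2CCO)cc2nc(NCc3cc(Cl)ccn3)oc12` is the starting point of the first core. In an ADME assay on cells (Hepatocyte, Rattus norvegicus, strain Wistar) for pharmacokinetics, read by LC-MS, with a stated time of 90 min, tested at 1 uM (a lower number here means slower removal, a higher number faster removal of the compound), compound 1 gives 20 mL/min/kg. Compound 2 `COc1cc(C(=O)N2CC(C)OCC2C2CC(O)C2)cc2nc(NCc3cc(Cl)ccn3)oc12` differs from it by 3-hydroxycyclobutyl in place of 2-hydroxyethyl on a saturated ring carbon and in this assay compound 2 gives 45 mL/min/kg; the step is a 2.3-fold higher number from compound 1 to compound 2 (0.35 log units; beyond the scatter).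

Compound 3 `COc1cc(C(=O)N2CC(C)OCC2CCO)cn2nc(NCc3cccc(Cl)c3)nc12` carries the 2-hydroxyethyl group on a second core; the difference between the two cores is not broken down here. In this assay compound 3 gives 31.7 mL/min/kg, a number within the scatter of both compound 1 and compound 2, so no order among these three is drawn.

Compound 4 `COc1cc(C(=O)N2CC(C)OCC2C2CC(O)C2)cn2nc(NCc3cccc(Cl)c3)nc12` is not yet measured and differs from compound 3 by 3-hydroxycyclobutyl in place of 2-hydroxyethyl on a saturated ring carbon. The place of this change reads the same, word for word, as in the pair of compound 1 and compound 2, so it is the same change, occurring twice among the compounds shown. Only one measured occurrence exists, so the expectation rests on it alone. For compound 4 in this assay a step of a 2.1-fold higher number from compound 3 to compound 4 (0.31 log units; beyond the scatter) is expected, kept a little short of the measured precedent because a 2.3-fold higher number from compound 1 to compound 2 (0.35 log units; beyond the scatter) was seen on a different core and a single example may not carry over in full. The estimate for compound 4 is 65 mL/min/kg, with a range from 35 mL/min/kg to 120 mL/min/kg.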

Compound 4, clearance: 50 mL/min/kg
Compound 4: the middle estimate sits 1.3-fold (0.11 log units) above what was measured, and the stated range covers the measured number.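

In this assay, 3-hydroxycyclobutyl in place of 2-hydroxyethyl gives a 1.6-fold higher number from compound 3 to compound 4 (0.20 log units; within the scatter), so on the core of compound 3 this step alone cannot be told apart from repeat measurement. Set beside the step on the core of compound 1, it cannot be separated from that earlier step: the same change on two cores in this assay, a 2.3-fold higher number (0.35 log units; beyond the scatter) from compound 1 to compound 2 and a 1.6-fold higher number (0.20 log units; within the scatter) from compound 3 to compound 4, 1.4-fold (0.15 log units) apart, within the scatter of two such steps

Going by these compounds alone, this is compatible with the change carrying over from one core to the other, but it does not establish that it does: only the step on the core of compound 1 lies beyond the scatter, two pairs are a narrow base, and neither pair explains the size of its step.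

Open, as far as these compounds go, is whether other groups on the same saturated ring carbon, such as a longer chain ending in a hydroxyl, an amine or a carboxylic acid, would give matching steps on the two cores. Also open, from the compounds shown here alone, is whether 3-hydroxycyclobutyl in place of 2-hydroxyethyl would give a step of similar size on a third core, or in hepatocytes from another species.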